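Chloro in place of fluoro on compound 1

The source may hold more compounds than are shown below. What is called first, only, known or untested is meant among the compounds shown, and "the series" means these compounds.

Among the compounds with values here, in a functional assay on Hep 3B2 cells (Homo sapiens) for inhibition, read by sulforhodamine B assay, with a stated time of 72 h (on this read-out higher numbers stand for weaker inhibition and lower numbers for stronger inhibition), compound 1 (`C[C@H](Nc1nc(N)nc(N)c1C#N)c1nn(-c2cccc(S(C)(=O)=O)c2)c2cc(F)ccc12`) gives 19700 nM, the only numeric value available so far. Compound 2 (`Cc1ccc2c(c1)c([C@H](C)Nc1ncnc3[nH]cnc13)nn2-c1cccnc1`) reads > 40000 nM, which is a limit of the assay. Compound 3 (`C[C@H](Nc1ncnc2[nH]cnc12)c1nn(-c2cccc(F)c2)c2cc(F)ccc12`) reads > 40000 nM, also a limit. Compound 4 (`C[C@H](Nc1nc(N)nc(N)c1C#N)c1nn(-c2cccc(S(C)(=O)=O)c2)c2cc(Cl)ccc12`) differs from compound 1 in one place: chloro in place of fluoro on an aromatic carbon of a six-membered aromatic ring of carbon only. Within the data shown here, no measured pair covers this change, so no direction can be drawn from the data. The expected step is a 1.1-fold lower number from compound 1 to compound 4 (0.04 log units; within the scatter), within the usual scatter of this assay. For compound 4 the estimated value is 18000 nM, with an expected range of 8000 nM to 40000 nM.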

Compound 4, half-maximal inhibitory concentration: 5110 nM
Beside the measured number, compound 4's estimate is 3.5-fold (0.55 log units) above it; measured number below the stated range.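

In this assay, chloro in place of fluoro gives a 3.9-fold lower number from compound 1 to compound 4 (0.59 log units; beyond the scatter). Within the data shown here, this is the first single-place change that can be read, and it shows that the number responds to the identity of the halogen on this aromatic carbon of the six-membered ring. The pair gives one step at one position, not a trend.

Going by these compounds, how bromo, methoxy or an amine would read at this carbon remains open. Compounds 2 and 3 add no number here, because each reads a limit of the assay: the limit of > 40000 nM in this assay, at which 2 of the 4 values shown sit.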